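Isobutyl on the ring carbon of the compound 1 core

A few compounds are considered here, and "the series" means these few. Any claim that something is new, unique, unknown or untested is made for them only; others in the source may bear on it.

compound 1 `CN1CC(=O)N(Cc2ccc(C(=O)NO)cc2)C1=O` gives 119 nM in an assay on isolated protein for inhibition of protein deacetylase HDAC6 (Homo sapiens), read by fluorescence, with stated times of 10 min and 2 h; a higher number here means a weaker inhibitor, a lower number a stronger inhibitor
compound 2 `O=C(NO)c1ccc(CN2C(=O)CN(Cc3ccccc3)C2=O)cc1` gives 12.5 nM
compound 3 `COc1ccc(CN2CC(=O)N(Cc3ccc(C(=O)NO)cc3)C2=O)cc1` gives 28.2 nM

Compound 1 has the highest number of the three; its steps to compound 2 and to compound 3 are both beyond the scatter. Compound 4 `CC(C)CC1C(=O)N(Cc2ccc(C(=O)NO)cc2)C(=O)N1C` differs from compound 1 by isobutyl in place of hydrogen on a saturated ring carbon. The measured steps concern a different place on the core: a 9.5-fold lower number from compound 1 to compound 2 (0.98 log units; beyond the scatter) and a 4.2-fold lower number from compound 1 to compound 3 (0.63 log units; beyond the scatter) both attach an aryl group to the saturated chain carbon bound to the ring nitrogen, and a 2.3-fold higher number from compound 2 to compound 3 (0.35 log units; beyond the scatter) varies that aryl. Among the measured compounds shown here, no measured step touches the saturated ring carbon, so none bears directly on the change to compound 4. For the measured compounds named here, the two additions onto compound 1 both lowered the number and are the only guide available; an added group at another place on the core cannot be assumed to do the same. For compound 4 a small lowering of the number is expected, within or just beyond the scatter, a 1.5-fold lower number from compound 1 to compound 4 (0.17 log units; within the scatter). The estimate for compound 4 is 80 nM, with a range from 30 nM to 250 nM.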

Compound 4, half-maximal inhibitory concentration: 251 nM
Compound 4: middle estimate off by 3.1-fold (0.50 log units), on the low side, outside the stated range (above it).
By their numbers in this assay, from the lowest: compound 2; then compound 3; then compound 1; then compound 4.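

In this assay, isobutyl on the saturated ring carbon gives a 2.1-fold higher number from compound 1 to compound 4 (0.32 log units; beyond the scatter), the first addition onto compound 1 in this set that raises the number rather than lowers it. The lowering seen with phenyl and 4-methoxyphenyl on the saturated chain carbon therefore does not carry over to this ring carbon, so adding a group to the core of compound 1 does not lower the number regardless of place. The step is modest, and no information here accounts for its direction.

As far as these compounds go, it remains open whether the rise belongs to isobutyl or to any group at this ring carbon, as a methyl group, a carboxylic acid or an amine here could show. Also open, from the compounds shown here alone, is whether phenyl on the saturated chain carbon still lowers the number when isobutyl is present on the ring carbon.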